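The source may report more compounds than this note shows. Statements on the series, on what has been measured and on what is new or still open speak of the compounds shown alone.

In an ADME assay on microsomes from liver (Homo sapiens) for metabolic stability, with a stated time of 10 min (a higher number here means that more of the compound is left, a lower number that less of the compound is left), compound 1 (`COc1ccc(CNC(=O)N2C[C@@H](c3ccc(C(O)(C(F)(F)F)C(F)(F)F)cc3)[C@@](C)(c3ccc(F)cc3)C2)cc1`) gives 68%, compound 2 (`C[C@]1(c2ccc(F)cc2)CN(C(=O)NCc2ccc(C#N)cc2)C[C@H]1c1ccc(C(O)(C(F)(F)F)C(F)(F)F)cc1`) gives 76% and compound 3 (`CC(=O)N1CCC(C(=O)N2C[C@@H](c3ccc(C(O)(C(F)(F)F)C(F)(F)F)cc3)[C@@](C)(c3ccc(F)cc3)C2)CC1`) gives 86%. Compound 3 lies clear of compound 1 but not of compound 2. The two steps read a number 18 percentage points higher from compound 1 to compound 3 (beyond the scatter) and a number 10 percentage points higher from compound 2 to compound 3 (within the scatter).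

Compound 4 (`C[C@]1(c2ccc(F)cc2)CN(C(=O)C2CCN(C(=O)C(N)=O)CC2)C[C@H]1c1ccc(C(O)(C(F)(F)F)C(F)(F)F)cc1`) keeps compound 3 except for one exchange, carbamoyl in place of methyl on a carbonyl carbon, which turns acetyl into carbamoylcarbonyl: carbamoyl in place of methyl on a carbonyl carbon.

Among the measured compounds shown here, no measured step touches this acetyl group directly. The closest guide in size is the exchange of one substituent, a number 8 percentage points higher from compound 1 to compound 2 (within the scatter), which stayed within the scatter. For the measured compounds named here, the only step beyond the scatter, from compound 1 to compound 3, replaced the whole group on the carbonyl carbon, a far larger exchange than this one. With compound 3 at 86% as the starting point, no step beyond the scatter is expected in this assay. The estimated step is no change at the digits printed from compound 3 to compound 4 (within the scatter). Compound 4 is expected at 86%, with an estimated range from 73% to 97%.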

Compound 4, percent of the compound remaining: 91%
Beside the measured number, compound 4's estimate is 5 percentage points below it, within the range that was stated.
By their numbers in this assay, from the lowest: compounds 1, 2, 3 and 4 (each within the scatter of the next, the first and the last beyond it).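

At the carbonyl carbon whose other neighbour is the amide-type nitrogen in a ring, this is the first exchange shown within the acetyl group: in this assay carbamoyl in place of methyl gives a number 5 percentage points higher from compound 3 to compound 4 (within the scatter), so the added heavy atoms, hydrogen-bond donor and hydrogen-bond acceptor leave the read-out within the scatter of compound 3. The change also sets the new compound clear of the benzyl ureas, with a number 15 percentage points higher from compound 2 to compound 4 (beyond the scatter) and a number 23 percentage points higher from compound 1 to compound 4 (beyond the scatter), whereas only compound 1 lay clear of compound 3. No measurement shown accounts for these numbers.

Open, on these data alone, is whether a carboxylic acid or a dimethylamino group in place of carbamoyl on this carbonyl carbon stays in the same range. As far as these compounds go, a longer chain at this place is equally open.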